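This account rests on a few compounds, and the source may have more. Where it says the series, first, only, none or still open, it means among the compounds named here.

Working notes on the series. The shared core appears in compound 1 `O=C1N/C(=N/c2csc(-c3ccc(Cl)cc3)c2)S/C1=C\c1ccccn1`, compound 2 `CN(C)c1ccc(/C=C2\S/C(=N\c3nc(-c4ccc(Cl)cc4)cs3)NC2=O)cc1` and compound 3 `Cc1ccc(/C=C2\S/C(=N\c3nc(-c4ccc(Cl)cc4)cs3)NC2=O)cc1`. In a functional assay on MDA-MB-231 cells (Homo sapiens) for cytotoxicity, read by MTT assay, with a stated time of 72 h (a higher number here means a weaker inhibitor, a lower number a stronger inhibitor), compound 1 gives 10900 nM, compound 2 gives 300 nM, and compound 3 gives 800 nM, the second highest of the three numbers, nearest to compound 2 and furthest from compound 1. Going by the values given here, the only single-point step measured so far, a 2.7-fold higher number from compound 2 to compound 3 (0.43 log units; beyond the scatter), is modest and beyond the scatter. Compound 4 `COc1ccc(/C=C2\S/C(=N\c3nc(-c4ccc(Cl)cc4)cs3)NC2=O)cc1` differs from compound 3 by methoxy in place of methyl on an aromatic carbon. Among the compounds with values here, no measured step exchanges methyl for methoxy at this position, so the step from compound 2 to compound 3 is only an indirect guide, and in this assay a step within the scatter, if anything toward a lower number, is expected. Compound 4 is therefore expected to give 600 nM, between 250 nM and 1500 nM. This estimate means a step of a 1.3-fold lower number from compound 3 to compound 4 (0.12 log units; within the scatter), expected to stay within the scatter.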

Compound 4, half-maximal inhibitory concentration: 300 nM
Estimate against measurement, compound 4: 2.0-fold (0.30 log units) above; low and high end bracket the measured number.
By their numbers in this assay, from the lowest: compounds 2 and 4 (each within the scatter of the next); then compound 3; then compound 1.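

The 4-methylphenyl to 4-methoxyphenyl change in this assay (a 2.7-fold lower number from compound 3 to compound 4 (0.43 log units; beyond the scatter)) shows that this position responds to methoxy in place of methyl by more than the scatter. Methoxy and dimethylamino at this position cannot be told apart (no change at the digits printed from compound 2 to compound 4 (within the scatter)), and both differ from methyl in the same direction. No measurement given here accounts for either step. Still open, going by these compounds, is how a hydroxyl, a fluorine or a longer alkoxy chain would read at this position, and whether the methyl to methoxy step carries over to the core of compound 1.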